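Working notes: from compound 1 to compound 4

A few compounds are considered here, and "the series" means these few. Any claim that something is new, unique, unknown or untested is made for them only; others in the source may bear on it.

Measured so far:
compound 1, `COc1ccc(-c2nnc(SCCn3c([N+](=O)[O-])cnc3C)o2)cc1`, 10600 nM
compound 2, `Cc1ncc([N+](=O)[O-])n1CCSc1nnc(-c2ccc(N(C)C)cc2)o1`, 14900 nM
compound 3, `COc1ccc(-c2nnc(SCCn3c([N+](=O)[O-])cnc3C)o2)c(O)c1`, 21800 nM

In a functional assay on MCF7 cells (Homo sapiens) for cytotoxicity, read by MTT assay, with a stated time of 48 h (on this read-out lower numbers stand for stronger inhibition and higher numbers for weaker inhibition), compound 1 gives the lowest of the three numbers. Its nearest neighbour is compound 2, reached by a 1.4-fold higher number from compound 1 to compound 2 (0.15 log units; within the scatter), a change that stays within the scatter, so no order between compound 1 and compound 2 can be read from these numbers. Compound 3 lies further off: a 2.1-fold higher number from compound 1 to compound 3 (0.31 log units; beyond the scatter), a modest worsening beyond the scatter.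

Compound 4, `Cc1ncc([N+](=O)[O-])n1CCSc1nnc(-c2cccs2)o1`, differs from compound 1 as follows: thiophen-2-yl in place of 4-methoxyphenyl on an aromatic carbon. Among the measured compounds shown here, none of the measured steps replaces the whole 4-methoxyphenyl group; the step from compound 1 to compound 2 only exchanges the group carried on that ring, and the step from compound 1 to compound 3 only adds a hydroxy to it. The closest guide is the small size of a 1.4-fold higher number from compound 1 to compound 2 (0.15 log units; within the scatter), which shows that a change to the group attached to the shared core need not shift the number much. For compound 4 in this assay the expectation is therefore a step of no clear direction, a 1.1-fold higher number from compound 1 to compound 4 (0.05 log units; within the scatter), essentially within the scatter. Compound 4 is estimated at 12000 nM, with a range from 5000 nM to 30000 nM.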

Compound 4, half-maximal inhibitory concentration: 25800 nM
The estimate for compound 4 lay 2.2-fold (0.33 log units) below the measured number, and the stated range covers the measured number.
By their numbers in this assay, from the lowest: compounds 1, 2, 3 and 4 (each within the scatter of the next, the first and the last beyond it).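

In this assay, exchanging the whole aryl group on this aromatic carbon of the shared core gives a 2.4-fold higher number from compound 1 to compound 4 (0.39 log units; beyond the scatter) and so shows that this position does respond to a change of ring, a modest worsening rather than a shift lost in the scatter. The earlier steps shown here altered only the groups on the benzene ring, whereas this one replaces a six-membered aromatic ring of carbon only with a five-membered aromatic ring with 1 hetero atom, and it removes the methoxy group in the same step, so the two changes cannot be told apart here. No available evidence accounts for the size or direction of this step.

The compounds shown leave open whether an unsubstituted phenyl at this position would stay close to compound 1 or fall closer to compound 4, which would separate the loss of the methoxy group from the exchange of the ring. They also leave open whether furan-2-yl, or thiophen-2-yl carrying a methoxy group, would behave like the thiophen-2-yl of compound 4.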